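Sulfonyl substituent: the step from compound 2 to compound 3

This account rests on a few compounds, and the source may have more. Where it says the series, first, only, none or still open, it means among the compounds named here.

In a functional assay on HepG2 cells (Homo sapiens) for antiproliferative activity, read by MTT assay, with a stated time of 48 h (a lower number here means a stronger inhibitor, a higher number a weaker inhibitor), compound 1 `CCCS(=O)(=O)n1cc(/C=C/C(=O)c2ccncc2)c2ccccc21` gives 46200 nM and compound 2 `O=C(/C=C/c1cn(S(=O)(=O)c2ccccc2[N+](=O)[O-])c2ccccc12)c1ccncc1` gives 31700 nM. For the measured compounds named here, compound 2 thus stands within the scatter of the only other measured compound. Compound 3 `O=C(/C=C/c1cn(S(=O)(=O)c2ccc(Cl)cc2Cl)c2ccccc12)c1ccncc1` carries 2,4-dichlorophenyl in place of 2-nitrophenyl on a sulfonyl sulfur. Going by the values given here, the one measured step at that sulfur, a 1.5-fold lower number from compound 1 to compound 2 (0.16 log units; within the scatter), replaced propyl with 2-nitrophenyl, so no step beyond the scatter is expected in this assay. The expected change is a 1.3-fold lower number from compound 2 to compound 3 (0.10 log units; within the scatter). The estimated value for compound 3 is 25000 nM, with an expected range of 9000 nM to 60000 nM.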

Compound 3, half-maximal inhibitory concentration: 14800 nM
The estimate for compound 3 lay 1.7-fold (0.23 log units) above the measured number; the range from low to high includes it.
By their numbers in this assay, from the lowest: compound 3; then compounds 2 and 1 (each within the scatter of the next).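

In this assay the sulfonyl sulfur now yields steps beyond the scatter, with a 2.1-fold lower number from compound 2 to compound 3 (0.33 log units; beyond the scatter) and a 3.1-fold lower number from compound 1 to compound 3 (0.49 log units; beyond the scatter) as modest steps, whereas the propyl to 2-nitrophenyl change stayed within it. So the group on this sulfur can move the number, and 2,4-dichlorophenyl is the only group shown to do so. Nothing available explains this step.

Still open, on these data alone, is whether a single chlorine on the phenyl ring would give the same step. Also open, as far as these compounds go, is how an amine or a carboxylic acid on that ring would compare.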